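Trifluoromethyl on the phenyl ring of compound 1

The source may report more compounds than this note shows. Statements on the series, on what has been measured and on what is new or still open speak of the compounds shown alone.

In a functional assay on HL-60 cells (Homo sapiens) for antiproliferative activity, read by MTT assay, with a stated time of 72 h (on this read-out lower numbers stand for stronger inhibition and higher numbers for weaker inhibition), compound 1 `N=C(NS(=O)(=O)c1ccccc1)N1CCN(c2cc3c(cc2F)c(=O)c(C(=O)O)cn3C2CC2)CC1` gives 43 nM, level with compound 2 `CCn1cc(C(=O)O)c(=O)c2cc(F)c(N3CCN(C(=N)NS(=O)(=O)c4ccccc4)CC3)cc21` at 43 nM. Compound 3 `N=C(NS(=O)(=O)c1ccccc1C(F)(F)F)N1CCN(c2cc3c(cc2F)c(=O)c(C(=O)O)cn3C2CC2)CC1` has trifluoromethyl in place of hydrogen on an aromatic carbon, ortho to a large group: trifluoromethyl in place of hydrogen on an aromatic carbon. For the measured compounds named here, the only measured step, no change at the digits printed from compound 1 to compound 2 (within the scatter), is a different change, ethyl in place of cyclopropyl on an aromatic nitrogen, so it sets no direct size for this one. No shift beyond the scatter is therefore expected in this assay, with wide uncertainty. The expected step is a 1.2-fold higher number from compound 1 to compound 3 (0.07 log units; within the scatter). For compound 3 the estimate is 50 nM, with an expected range of 15 nM to 170 nM.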

Compound 3, half-maximal inhibitory concentration: 43 nM
The estimate for compound 3 lay 1.2-fold (0.07 log units) above the measured number; the measured number falls inside the stated range.
By their numbers in this assay, from the lowest: compounds 1, 2 and 3 (each within the scatter of the next).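

In this assay, going from phenyl to 2-(trifluoromethyl)phenyl gives no change at the digits printed from compound 1 to compound 3 (within the scatter), the first read on this ring, as the earlier step concerned only the group on the aromatic nitrogen. This place on the ring therefore accepts trifluoromethyl with no shift beyond the scatter. No measurement shown here accounts for this result. On these data alone, whether an amine, a carboxylic acid or a methoxy group at the same place would also leave the number unchanged stays open. Also open, as far as these compounds go, is whether trifluoromethyl gives the same result with ethyl on the aromatic nitrogen.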